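Moving the Chlorine on an Inactive Series

The source may report more compounds than this note shows. Statements on the series, on what has been measured and on what is new or still open speak of the compounds shown alone.

Of the compounds shown here, three have been read in an ADME assay on MCF-10A cells (Homo sapiens) for inhibition, with a stated time of 48 h (on this read-out lower numbers stand for stronger inhibition and higher numbers for weaker inhibition), and none gives a number. Compound 1 `O=C(Nc1ccc(I)cc1)N1CCC[C@H]1c1nc(-c2ccccc2)no1` gives > 50000 nM, which is a limit. Compound 2 `Cc1ccccc1-c1noc([C@@H]2CCCN2C(=O)Nc2ccc(Cl)cc2)n1` gives > 50000 nM, again a limit. Compound 3 `O=C(Nc1ccc(Cl)cc1)N1CCC[C@H]1c1nc(-c2ccccc2Cl)no1` also stands only at a limit, > 50000 nM. Within the data shown here, the series so far therefore rests on (the limit of > 50000 nM in this assay, at which 3 of the 3 values shown sit).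

Compound 4 `O=C(Nc1ccc(Cl)cc1)N1CCC[C@H]1c1nc(-c2cccc(Cl)c2)no1` has the same atoms as compound 3, joined differently, with 3-chlorophenyl in place of 2-chlorophenyl on an aromatic carbon. Among the measured compounds shown here, the only measured step at this group is a step that the two limits leave unreadable from compound 2 to compound 3, with chloro in place of methyl on an aromatic carbon, so it offers no size to carry over.

With compound 3 at > 50000 nM, the expectation rests on that limit alone, and compound 4 will probably be reported as a limit too. No change beyond the scatter is expected, and the estimated step is a step that the limit leaves unreadable from compound 3 to compound 4. Compound 4 is expected at 60000 nM, with an estimated range of 25000 nM to 100000 nM.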

Compound 4, half-maximal inhibitory concentration: > 50000 nM
Compound 4 ended at the assay's limit; the forecaster's own chance of this, stated with the estimate: 85%; the middle value does not contradict the limit.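

Compound 4 also stands only at a limit, so its steps from compound 2 and from compound 3 cannot be read. The compounds shown leave open whether any of these changes of group alters inhibition in this assay, as all the results remain limits: the limit of > 50000 nM in this assay, at which 4 of the 4 values shown sit.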